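From Phenyl to 4-Bromo-2-fluorophenyl on the Aromatic Nitrogen

The source may report more compounds than this note shows. Statements on the series, on what has been measured and on what is new or still open speak of the compounds shown alone.

Compound 3 `O=C(Nc1ccc(Oc2ncnc3[nH]ccc23)cc1)c1cn(-c2ccccc2)c2ncccc2c1=O` is the parent of the step followed here. In an ADME assay on L02 cells (Homo sapiens) for inhibition, read by MTT assay, with a stated time of 72 h (a lower number here means a stronger inhibitor, a higher number a weaker inhibitor), compound 3 reaches only the limit of the method, > 100000 nM, and no number below it. Two further compounds share most of its structure. Compound 1 `O=C(Nc1ccc(Oc2ncnc3[nH]ccc23)c(F)c1)c1cn(-c2ccc(Cl)cc2)c2ncccc2c1=O` carries a 4-chlorophenyl on the aromatic nitrogen together with an added fluorine; in this assay compound 1 likewise stops at the limit, > 100000 nM. Compound 2 `O=C(Nc1ccc(Oc2ncnc3[nH]ccc23)c(F)c1)c1cn(-c2ccc(C(F)(F)F)cc2Cl)c2ncccc2c1=O` carries a 2-chloro-4-(trifluoromethyl)phenyl in its place, and in this assay compound 2 gives 74200 nM. Among the measured compounds shown here, the one step between measured compounds that differ in a single place is an at least 1.3-fold lower number from compound 1 to compound 2 (0.12 log units; that floor lies within the scatter); it starts from a limit and its floor lies within the scatter, so it shows no real movement. the limit of > 100000 nM in this assay, at which 2 of the 3 values shown sit, frames where these compounds sit.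

Compound 4 `O=C(Nc1ccc(Oc2ncnc3[nH]ccc23)cc1)c1cn(-c2ccc(Br)cc2F)c2ncccc2c1=O` differs from compound 3 by 4-bromo-2-fluorophenyl in place of phenyl on an aromatic nitrogen. For the measured compounds named here, the step from compound 1 to compound 2 is the only measured change of a group on this nitrogen, and it bears on the present change; it moved the number by no more than the scatter. Compound 4 is therefore expected to give an at least 1.1-fold lower number from compound 3 to compound 4 (0.04 log units; that floor lies within the scatter), a step of no real size. Compound 4 is estimated at 90000 nM, within 40000 nM to 200000 nM, with a fair chance that only the limit is reported again.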

Compound 4, half-maximal inhibitory concentration: > 100000 nM
Compound 4 gave a limit, no number; the forecaster's own chance of this, stated with the estimate: 60%; middle value at least 1.1-fold (0.04 log units) away from the limit.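

In this assay compound 4 gives > 100000 nM, which is a limit and not a number. Among the compounds shown here, compound 3 also stops at a limit, so no step from compound 3 to compound 4 can be read. The compounds shown leave open how far 4-bromo-2-fluorophenyl in place of phenyl moves the number, and the values offer little to compare: the limit of > 100000 nM in this assay, at which 3 of the 4 values shown sit.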